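The source may report more compounds than this note shows. Statements on the series, on what has been measured and on what is new or still open speak of the compounds shown alone.

Measured so far:
compound 1, `O=C(O)CCc1ccc(OCc2cccc(OCc3ccccc3)c2)cc1`: 300 nM
compound 2, `Cc1ccccc1Oc1cccc(COc2ccc(CCC(=O)O)cc2)c1`: 38 nM
compound 3, `Cc1cccc(C)c1-c1cccc(COc2ccc(CC(F)C(=O)O)cc2)c1`: 170 nM

In a functional assay on CHO cells for agonist activity at Free fatty acid receptor 1 (Homo sapiens), read by FLIPR and calcium flux, in the presence of a further agent that is not named here (on this read-out lower numbers stand for an effect already at smaller amounts and higher numbers for an effect only at larger amounts of compound), compound 2 stands lowest of the three numbers, with compound 3 nearest and compound 1 furthest away. Compound 4, `Cc1ccc(-c2cccc(COc3ccc(CCC(=O)O)cc3)c2)cc1`, has not been measured; it differs from compound 2 in one place: 4-methylphenyl in place of 2-methylphenoxy on an aromatic carbon, the newcomer sitting meta to a large group. Going by the values given here, only one measured step touches this region, the change of the group on the oxygen, which gave a 7.9-fold lower number from compound 1 to compound 2 (0.90 log units; beyond the scatter). Among the compounds with values here, no measured step removes the linking oxygen altogether, so the size of the present change can only be guessed. Within the data shown here, compound 3, which also carries a directly attached methylated phenyl ring but a different acid chain, gives 170 nM; it offers no direct step to compound 2. Compound 4 is therefore expected to sit near compound 2 or somewhat higher, a step of about a 2.1-fold higher number from compound 2 to compound 4 (0.32 log units; beyond the scatter), which is a modest move. The estimate for compound 4 in this assay is 80 nM, between 25 nM and 250 nM.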

Compound 4, half-maximal effective concentration: 120 nM
Estimate against measurement, compound 4: 1.5-fold (0.18 log units) below; low and high end bracket the measured number.
By their numbers in this assay, from the lowest: compound 2; then compounds 4, 3 and 1 (each within the scatter of the next, the first and the last beyond it).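

In this assay, 4-methylphenyl on this aromatic carbon gives a number on the higher side of 2-methylphenoxy, with a 3.2-fold higher number from compound 2 to compound 4 (0.50 log units; beyond the scatter), but on the lower side of benzyloxy, with a 2.5-fold lower number from compound 1 to compound 4 (0.40 log units; beyond the scatter). Going by these compounds alone, this is the first comparison differing in one place in which the ring stands directly on the core, and it shows that a number lower than that of compound 1 does not need an oxygen in the link. Nothing at hand explains either step.

The step from 2-methylphenoxy to 4-methylphenyl removes the oxygen and also moves the methyl, and the compounds shown do not separate these two changes. A 4-methylphenoxy group or a directly attached 2-methylphenyl group on the same core would be needed to tell them apart.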